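A few compounds are considered here, and "the series" means these few. Any claim that something is new, unique, unknown or untested is made for them only; others in the source may bear on it.

Compound 2 `COC(=O)c1cc(-c2cccc(NC(=O)c3ccc(/C=C/C(=O)c4ccc(Br)cc4)cc3)c2)on1` is the point of departure. In an ADME assay on Vero cells (Chlorocebus sabaeus) for cytotoxicity, read by MTT assay, with a stated time of 72 h (on this read-out higher numbers stand for lower toxicity in this test and lower numbers for higher toxicity in this test), compound 2 gives > 20 ug/mL, which is a limit of the assay and not a number. Compound 1 `CCCOc1ccc(C(=O)/C=C/c2ccc(C(=O)Nc3cccc(-c4cc(C(=O)OC)no4)c3)cc2)cc1` gives > 40 ug/mL in this assay, again a limit. The step that the two limits leave unreadable from compound 1 to compound 2 therefore cannot be sized; the two limits the limit of > 20 ug/mL in this assay, at which 1 of the 2 values shown sits, and the limit of > 40 ug/mL in this assay, at which 1 of the 2 values shown sits, are all that stands behind it. Compound 3 `COC(=O)c1cc(-c2cccc(NC(=O)c3ccc(/C=C/C(=O)c4ccc(C)c(F)c4)cc3)c2)on1` carries 3-fluoro-4-methylphenyl in place of 4-bromophenyl on a carbonyl carbon. No readable measured step bears on this change, so no shift beyond the scatter is expected. Compound 3 is estimated at 30 ug/mL (range 12 ug/mL to 80 ug/mL), an expected step that the limit leaves unreadable from compound 2 to compound 3.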

Compound 3, half-maximal cytotoxic concentration: > 50 ug/mL
Compound 3: no number, only a limit (the forecaster's own chance of this, stated with the estimate: 65%); middle value at least 1.6-fold (0.22 log units) away from the limit.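

In this assay, among the compounds shown here, compound 3 gives > 50 ug/mL, a limit and not a number, so no step from compound 1 or compound 2 to compound 3 can be read. Left open is whether 4-propoxyphenyl, 4-bromophenyl and 3-fluoro-4-methylphenyl on the carbonyl carbon differ at all in this assay.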